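A Trifluoromethyl Group Where Two Limits Already Sit

The compounds below may be only part of what the source reports. "The series", "measured", "known", "first", "only" and "open" are said of these compounds alone.

Measured compounds:
Compound 1, `C#CCN(Cc1ccc2nc(C)nc(O)c2c1)c1ccccc1`, gives only a limit in a functional assay on L1210 cells (Mus musculus) for inhibition; on this read-out higher numbers stand for weaker inhibition and lower numbers for stronger inhibition: > 6500 nM.
Compound 2, `C#CCN(Cc1ccc2nc(C)nc(O)c2c1)c1cccc(C)c1`, gives only a limit in this assay: > 5000 nM.

For the measured compounds named here, compound 1 therefore stands not at a number but at a limit of this assay, and the same holds for compound 2, so what the two values show is only that neither compound inhibits strongly enough to be measured. Going by the values given here, the single measured step, a step that the two limits leave unreadable from compound 1 to compound 2, cannot be read in size or direction, since one value sits at the limit of > 5000 nM in this assay, at which 1 of the 2 values shown sits, and the other at the limit of > 6500 nM in this assay, at which 1 of the 2 values shown sits.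

Compound 3, `C#CCN(Cc1ccc2nc(C)nc(O)c2c1)c1cccc(C(F)(F)F)c1`, differs from compound 1 by trifluoromethyl in place of hydrogen on an aromatic carbon. Among the compounds with values here, no measured step bears on this change, and the one step that exists is unreadable, so no size of step can be taken from the data. What the two limits for compound 1 and compound 2 show is that the shared core with a propargyl-bearing aniline sits at the weak end of this assay, and compound 3 is expected to remain there. The estimate for compound 3 in this assay is 10000 nM, within 3000 nM to 40000 nM. This expected estimate amounts to a step that the limit leaves unreadable from compound 1 to compound 3, most likely again reported only as a limit.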

Compound 3, half-maximal inhibitory concentration: > 2200 nM
Compound 3: only a limit was reported (the forecaster's own chance of this, stated with the estimate: 75%); the middle value does not contradict the limit.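

In this assay compound 3 gives > 2200 nM, which is a limit and not a number. For the compounds shown here, compound 1 and compound 2 also stand only at limits, so no step among compound 1, compound 2 and compound 3 can be read. The compounds shown leave open how strongly each inhibits, and whether methyl or trifluoromethyl in place of hydrogen changes inhibition at all.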